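Triazole amide series: from compound 3 to compound 4

This account rests on a few compounds, and the source may have more. Where it says the series, first, only, none or still open, it means among the compounds named here.

Measured so far in a functional assay on CHO cells for antagonist activity at prostaglandin E2 receptor EP4 subtype (Homo sapiens), read by calcium flux, with a stated time of 15 min; on this read-out lower numbers stand for stronger inhibition and higher numbers for weaker inhibition:
compound 1, `C[C@H](NC(=O)c1c(C(F)(F)F)nnn1Cc1cccc(C(F)(F)F)c1)c1ccc(C(=O)O)cc1`, gives 1970 nM
compound 2, `C[C@H](NC(=O)c1c(-c2ccccc2)nnn1Cc1ccccc1)c1ccc(C(=O)O)cc1`, gives 647 nM
compound 3, `COc1ccc(Cn2nnc(-c3ccccc3)c2C(=O)N[C@@H](C)c2ccc(C(=O)O)cc2)cc1`, gives 9.3 nM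

Compound 3 stands lowest of the three numbers in this assay ; compound 2 is nearest and compound 1 furthest, both steps to it beyond the scatter. For the measured compounds named here, the only single-point step available is the one that produced compound 3: a 70-fold lower number from compound 2 to compound 3 (1.84 log units; beyond the scatter), a methoxy in place of hydrogen on an aromatic carbon.

Compound 4, `C[C@H](NC(=O)c1c(-c2ccccc2)nnn1CCOc1ccc(F)cc1)c1ccc(C(=O)O)cc1`, differs from compound 3 in one place: (4-fluorophenoxy)methyl in place of 4-methoxyphenyl on a saturated chain carbon bound to an aromatic nitrogen. Going by the values given here, no measured step covers this change directly. The step from compound 2 to compound 3 bears on it only in that the methoxy-bearing ring which gave that large gain is the part that leaves, while the entering group carries fluorine and a longer link to the aromatic nitrogen. On that basis a higher number is expected for compound 4 in this assay , of a size comparable to, but likely smaller than, the reverse of the step from compound 2 to compound 3, so an expected step of a 16-fold higher number from compound 3 to compound 4 (1.21 log units; beyond the scatter). The estimate for compound 4 is 150 nM, with a range of 30 nM to 900 nM.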

Compound 4, half-maximal inhibitory concentration: 3.1 nM
Beside the measured number, compound 4's estimate is 48-fold (1.68 log units) above it; measured number below the stated range.
By their numbers in this assay, from the lowest: compound 4; then compound 3; then compound 2; then compound 1.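

Working notes: the 4-methoxyphenyl of compound 3 is not needed for a low number in this assay, since (4-fluorophenoxy)methyl in its place on a saturated chain carbon bound to an aromatic nitrogen gives a 3.0-fold lower number from compound 3 to compound 4 (0.48 log units; beyond the scatter). Set against the phenyl at the same place, the entering group gives a 210-fold lower number from compound 2 to compound 4 (2.32 log units; beyond the scatter), a larger change than a 70-fold lower number from compound 2 to compound 3 (1.84 log units; beyond the scatter), so both 4-methoxybenzyl and the longer 2-(4-fluorophenoxy)ethyl sit at low numbers in this assay and the place is not limited to a benzyl-type group. Nothing measured here accounts for the gain from either group.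

Compound 4 changes the link and the ring substituent together, so the shares of the ether oxygen and the fluorine in its number stay apart from view, and 2-phenoxyethyl and 2-(4-methoxyphenoxy)ethyl at this place would separate them. On these data alone, how far the chain can run also stays open, with 3-(4-fluorophenoxy)propyl as the next longer chain to read against compound 4 in this assay.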